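The source may hold more compounds than are shown below. What is called first, only, known or untested is meant among the compounds shown, and "the series" means these compounds.

Working notes on the series. Among the compounds with values here, compound 3 `c1cn2cc(-c3ccsc3)nc(-c3ccc4ncn(C5CCCCC5)c4c3)c2n1` sits lowest of the three numbers so far in a functional assay on A549 cells (Homo sapiens) for inhibition, read by sulforhodamine B assay, with a stated time of 48 h, tested at 10 uM (on this read-out lower numbers stand for less inhibition and higher numbers for more inhibition at the one concentration tested (going by the name of the read-out)), at 3.97%. Its nearest neighbour is compound 1 `Brc1cn2ccnc2c(-c2ccc3ncn(C4CCCCC4)c3c2)n1`, which gives 9.36%, the two lying within the scatter of each other; the furthest is compound 2 `COc1ccc(-c2cn3ccnc3c(-c3ccc4ncn(C5CCCCC5)c4c3)n2)cc1`, which gives 68.6%, with a number 64.6 percentage points lower from compound 2 to compound 3 (beyond the scatter).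

The next compound, compound 4 `Fc1ccccc1-c1cn2ccnc2c(-c2ccc3ncn(C4CCCCC4)c3c2)n1`, differs from compound 3 in one place: 2-fluorophenyl in place of thiophen-3-yl on an aromatic carbon.

Within the data shown here, two measured steps bear on this. The step of a number 64.6 percentage points lower from compound 2 to compound 3 (beyond the scatter) and the step of a number 59.2 percentage points higher from compound 1 to compound 2 (beyond the scatter) both show that the single six-membered carbon-only ring tried so far, 4-methoxyphenyl, stands far above bromo and thiophen-3-yl, while a number 5.4 percentage points lower from compound 1 to compound 3 (within the scatter) shows bromo and thiophen-3-yl as indistinguishable. Compound 4 carries a six-membered carbon-only ring but lacks the acceptor of 4-methoxyphenyl, so a rise from compound 3 is expected, though of uncertain size. The expected step is a number 36 percentage points higher from compound 3 to compound 4 (beyond the scatter), giving compound 4 an estimated value in this assay of 40%, with a range from 10% to 72%.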

Compound 4, a percentage reported as inhibition, at one concentration (the size of the read-out at that concentration, not a potency): 9.1%
Estimate against measurement, compound 4: 30.9 percentage points above; the measured number lies below the stated range.
By their numbers in this assay, from the lowest: compounds 3, 4 and 1 (each within the scatter of the next); then compound 2.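

In this assay, a six-membered carbon-only aromatic ring at this position does not by itself bring a high number: a number 5.1 percentage points higher from compound 3 to compound 4 (within the scatter) and a number 0.3 percentage points lower from compound 1 to compound 4 (within the scatter) leave 2-fluorophenyl level with thiophen-3-yl and bromo, while a number 59.5 percentage points lower from compound 2 to compound 4 (beyond the scatter) sets it far under 4-methoxyphenyl. The high number of compound 2 therefore goes with 4-methoxyphenyl alone among the four groups shown, not with an aromatic ring as such. Nothing available explains the gap between 4-methoxyphenyl and 2-fluorophenyl.

The methoxy group and the fluorine differ both in kind and in where they sit on the phenyl ring, and the compounds shown do not separate these two changes. Going by these compounds, it also remains open whether a phenyl ring carrying an amine or a carboxylic acid would fall with compound 4 or rise towards compound 2.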